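This account rests on a few compounds, and the source may have more. Where it says the series, first, only, none or still open, it means among the compounds named here.

Compound 3 `NC1CCC(Nc2nc(NCc3ccc(-c4ccsc4)cc3)c3ncn(C4CCCC4)c3n2)CC1` shows the lowest number of the three measured compounds in a functional assay on HCT-116 cells (Homo sapiens) for inhibition, with a stated time of 72 h (on this read-out lower numbers stand for stronger inhibition and higher numbers for weaker inhibition), at 315 nM. Compound 2 `NC1CCC(Nc2nc(NCc3ccc(-c4cccc(F)c4)cc3)c3ncn(C4CCCC4)c3n2)CC1` stands nearest with 551 nM, and compound 1 `NC1CCC(Nc2nc(NCc3ccc(Br)cc3)c3ncn(C4CCCC4)c3n2)CC1` furthest with 790 nM. The gaps were a 1.7-fold lower number from compound 2 to compound 3 (0.24 log units; within the scatter) and a 2.5-fold lower number from compound 1 to compound 3 (0.40 log units; beyond the scatter). Compound 4 `NC1CCC(Nc2nc(NCc3ccc(-c4ccccc4O)cc3)c3ncn(C4CCCC4)c3n2)CC1` differs from compound 3 in a single place: 2-hydroxyphenyl in place of thiophen-3-yl on an aromatic carbon. Among the measured compounds shown here, the steps that bear on this change are those that put an aromatic group in the same place, a 1.4-fold lower number from compound 1 to compound 2 (0.16 log units; within the scatter) and a 2.5-fold lower number from compound 1 to compound 3 (0.40 log units; beyond the scatter), and the exchange of one such group for another, a 1.7-fold lower number from compound 2 to compound 3 (0.24 log units; within the scatter), all of them small. The expectation is therefore a step of no more than modest size, most likely a slightly higher number, a 1.3-fold higher number from compound 3 to compound 4 (0.12 log units; within the scatter). Compound 4 is estimated at 420 nM, expected to fall between 180 nM and 950 nM.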

Compound 4, half-maximal inhibitory concentration: 4350 nM
Estimate against measurement, compound 4: 10-fold (1.02 log units) below; the whole stated range lies below it.
By their numbers in this assay, from the lowest: compounds 3, 2 and 1 (each within the scatter of the next, the first and the last beyond it); then compound 4.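

At this position, para to a large group, the aromatic groups of compound 2 and compound 3 had stayed level with or under bromo, yet 2-hydroxyphenyl brings a 14-fold higher number from compound 3 to compound 4 (1.14 log units; beyond the scatter) in this assay and thus shows that the exchange of one aromatic group for another can be large here. The same group gives a 7.9-fold higher number from compound 2 to compound 4 (0.90 log units; beyond the scatter) and also a 5.5-fold higher number from compound 1 to compound 4 (0.74 log units; beyond the scatter) so an aromatic group in this place does not by itself lower the number.

From the compounds shown here alone, whether a plain phenyl, a 2-methoxyphenyl or a 3-hydroxyphenyl would sit nearer compound 3 or compound 4 remains open. Nothing at hand explains the rise.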